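A few compounds are considered here, and "the series" means these few. Any claim that something is new, unique, unknown or untested is made for them only; others in the source may bear on it.

Measured compounds:
compound 1, `S=C(Nc1ccc(Cl)cc1)Nc1nc2ccccc2s1`, 39000 nM
compound 2, `Fc1ccc2nc(NC(=S)Nc3ccc(Cl)cc3)sc2c1`, 31200 nM
compound 3, `Clc1cccc2sc(Nc3nc4ccccc4s3)nc12`, > 50000 nM

Compound 1 and compound 2 share a core, and the difference between them is fluoro in place of hydrogen on an aromatic carbon. In a functional assay on THP-1 cells (Homo sapiens) for cytotoxicity, read by MTT assay, with a stated time of 48 h (on this read-out higher numbers stand for weaker inhibition and lower numbers for stronger inhibition), compound 1 gives 39000 nM and compound 2 gives 31200 nM, a step of a 1.3-fold lower number from compound 1 to compound 2 (0.10 log units; within the scatter). The two numbers are therefore not told apart by this assay.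

Compound 3 is built on a different core; the difference between the two cores is not broken down here. Compound 3 gives > 50000 nM, which is a limit of the assay and not a number. This is the only one of the three results that sits at the limit of > 50000 nM in this assay, at which 1 of the 3 values shown sits.

Compound 4, `Fc1ccc2nc(Nc3nc4c(Cl)cccc4s3)sc2c1`, has not yet been measured in this assay. It differs from compound 3 by fluoro in place of hydrogen on an aromatic carbon, the same change that separates compound 1 from compound 2, and it is made on the same kind of position. Within the data shown here, the only measured step of this change, a 1.3-fold lower number from compound 1 to compound 2 (0.10 log units; within the scatter), lies within the scatter, and compound 3 itself gave only a limit. Among the measured compounds shown here, on that basis the step from compound 3 to compound 4 is expected to be a step that the limit leaves unreadable from compound 3 to compound 4, that is, no step that the assay could resolve. Compound 4 is thus expected to fall near 60000 nM, with a likely range from 30000 nM to 150000 nM, and it is thought quite possible that the assay will again report only a limit for compound 4 rather than a number.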

Compound 4, half-maximal inhibitory concentration: 36200 nM
Beside the measured number, compound 4's estimate is 1.7-fold (0.22 log units) above it, and the stated range covers the measured number.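

In this assay, fluoro in place of hydrogen on an aromatic carbon of the core of compound 3 gives an at least 1.3-fold lower number from compound 3 to compound 4 (0.14 log units; that floor lies within the scatter). Compound 3 gives > 50000 nM, which is a limit of the assay and not a number. The two results fit a change that does little on either core, but they do not exclude a larger step on the core of compound 3, so they do not show that the size of the step carries over from one core to the other: the same change on two cores in this assay, a 1.3-fold lower number (0.10 log units; within the scatter) from compound 1 to compound 2 and an at least 1.3-fold lower number (0.14 log units; that floor lies within the scatter) from compound 3 to compound 4; the limit leaves it open whether they differ

The compounds shown leave open whether a group other than fluoro on the same aromatic carbon, such as methoxy, trifluoromethyl or an amine, would give a step beyond the scatter on either core. They also leave open whether a carboxylic acid or a longer chain in that place would give the same step on both cores in this assay.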